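From 2,5-difluorophenyl to 2-methoxyphenyl on the shared core

The compounds below may be only part of what the source reports. "The series", "measured", "known", "first", "only" and "open" are said of these compounds alone.

In a physicochemical assay for solubility, in phosphate buffer, at pH 7.4 (a lower number here means a less soluble compound, a higher number a more soluble compound), compound 1 `OC[C@@H]1[C@@H](O)[C@H](O)[C@@H](O)CN1CCCCCCOc1cc(F)ccc1F` gives 292000 nM and stands within the scatter of compound 2 `OC[C@@H]1[C@@H](O)[C@H](O)[C@@H](O)CN1CCCCCCOc1cccc(C(F)(F)F)c1` at 278000 nM on the two numbers available. Compound 3 `COc1ccccc1OCCCCCCN1C[C@H](O)[C@@H](O)[C@H](O)[C@H]1CO` is not yet measured. It carries 2-methoxyphenyl in place of 2,5-difluorophenyl on an oxygen on a saturated carbon. Within the data shown here, no measured step covers this change. Among the measured compounds shown here, the only guide is that compound 1 (292000 nM) and compound 2 (278000 nM) carry different aromatic groups yet lie within the scatter. In this assay the expected step of a 1.0-fold higher number from compound 1 to compound 3 (0.01 log units; within the scatter) stays within the scatter, with no direction favoured. For compound 3 the estimate is 300000 nM, with an expected range from 150000 nM to 600000 nM in this series.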

Compound 3, solubility: 293000 nM
Compound 3: the middle estimate sits 1.0-fold (0.01 log units) above what was measured; low and high end bracket the measured number.
By their numbers in this assay, from the lowest: compounds 2, 1 and 3 (each within the scatter of the next).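

In this assay, 2-methoxyphenyl in place of 2,5-difluorophenyl on an oxygen on a saturated carbon gives a 1.0-fold higher number from compound 1 to compound 3 (0.00 log units; within the scatter), the first single-place step read in this series. The entering group carries a hydrogen-bond acceptor that the leaving group lacks, yet the step lies within the scatter. No supporting data on hand offer a reason for this result. Open, as far as these compounds go, is whether an amine or a carboxylic acid on the aromatic group would give a step beyond the scatter. From the compounds shown here alone, the outcome with a longer chain also remains open.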